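Amino in Place of Nitro on a Biaryl Ester

The compounds below may be only part of what the source reports. "The series", "measured", "known", "first", "only" and "open" are said of these compounds alone.

Compound 3 `CCOC(=O)c1cccc(-c2ccc(OCC)c([N+](=O)[O-])c2)c1` bears a nitro group on the ethoxy-carrying ring of the shared core. In an assay on COS-7 cells for inhibition of patatin-like phospholipase domain-containing protein 2 (Mus musculus) (a higher number here means a weaker inhibitor, a lower number a stronger inhibitor), compound 3 gives 200000 nM, the highest of the two numbers shown. Its nearest neighbour is compound 1 `CCOC(=O)c1cccc(-c2ccc(OCC)cc2)c1`, which in this assay gives 50000 nM. Compound 2 `CCOC(=O)c1cccc(-c2ccncc2)c1` is recorded in this assay only as a limit, > 200000 nM, and not as a number. For the measured compounds named here, the one measured step with a numerical outcome is a 4.0-fold higher number from compound 1 to compound 3 (0.60 log units; beyond the scatter), where the nitro group went in for a hydrogen.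

Compound 4 `CCOC(=O)c1cccc(-c2ccc(OCC)c(N)c2)c1` differs from compound 3 by amino in place of nitro on an aromatic carbon. Going by the values given here, no measured pair contains an amino group, so the only step that bears on this change is the one in which the nitro group entered: that step raised the number modestly, and taking the nitro group out again is the part of the present change that the data speak to. Going by these compounds, what the amino group itself does remains open.

Compound 4 is therefore expected to give about 80000 nM in this assay, in a range from 30000 nM to 200000 nM. This estimate for compound 4 means a step of a 2.5-fold lower number from compound 3 to compound 4 (0.40 log units; beyond the scatter), a modest move toward a lower number.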

Compound 4, half-maximal inhibitory concentration: 140000 nM
Beside the measured number, compound 4's estimate is 1.8-fold (0.24 log units) below it; low and high end bracket the measured number.
By their numbers in this assay, from the lowest: compound 1; then compounds 4 and 3 (each within the scatter of the next).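

Amino in place of nitro gives a 1.4-fold lower number from compound 3 to compound 4 (0.15 log units; within the scatter), so in this assay the two groups cannot be told apart on this aromatic carbon, ortho to an ethoxy group. Amino in place of hydrogen gives a 2.8-fold higher number from compound 1 to compound 4 (0.45 log units; beyond the scatter), and together with a 4.0-fold higher number from compound 1 to compound 3 (0.60 log units; beyond the scatter) this shows that the number stands higher than that of compound 1 with either of the two groups on this carbon, and that the rise seen with the nitro group is not specific to nitro among these compounds. Compound 2 is recorded only as a limit and adds no reading on this change: the limit of > 200000 nM in this assay, at which 1 of the 4 values shown sits.

Whether any group on this carbon would leave the number as low as hydrogen does remains open, since only nitro and amino are shown there, and a fluorine, a methyl or a hydroxyl could point either way. Also open, going by these compounds, is whether the same rise would hold with the ethoxy group exchanged for a methoxy group, or with the ethyl ester exchanged for a carboxylic acid.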